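The compounds below may be only part of what the source reports. "The series", "measured", "known", "first", "only" and "open" are said of these compounds alone.

For the measured compounds named here, compound 3 `O=[N+]([O-])c1cccc(Nc2nc(SCc3ccc(C(F)(F)F)cc3)nc3ccccc23)c1` is the only compound here with an actual number in a functional assay on MDA-MB-231 cells (Homo sapiens) for cytotoxicity, read by MTT assay, with a stated time of 72 h; a higher number here means a weaker inhibitor, a lower number a stronger inhibitor: compound 3 gives 31500 nM. Compound 1 `FC(F)(F)c1ccc(CSc2nc(Nc3ccccc3C(F)(F)F)c3ccccc3n2)cc1` reaches only the assay limit, giving > 50000 nM in this assay. Compound 2 `FC(F)(F)c1ccc(CSc2nc(Nc3ccccc3Cl)c3ccccc3n2)cc1` likewise gives only the limit > 50000 nM. So compound 3 stands as the single readable value, the other two sitting at a limit (the limit of > 50000 nM in this assay, at which 2 of the 3 values shown sit). Compound 4 `Fc1ccc(Nc2nc(SCc3ccc(C(F)(F)F)cc3)nc3ccccc23)cc1Cl` differs from compound 3 by 3-chloro-4-fluorophenyl in place of 3-nitrophenyl on a nitrogen on an aromatic ring. Going by the values given here, the steps that bear on this run the opposite way, an at least 1.5-fold lower number from compound 1 to compound 3 (0.20 log units; that floor lies within the scatter) and an at least 1.5-fold lower number from compound 2 to compound 3 (0.20 log units; that floor lies within the scatter), both only floors. Reversing that, from 3-nitrophenyl back to 3-chloro-4-fluorophenyl, may drift toward the limit again, though the earlier groups were 2-chlorophenyl and 2-(trifluoromethyl)phenyl. Compound 4 is expected to give about 45000 nM, between 15000 nM and 120000 nM, an expected step of a 1.4-fold higher number from compound 3 to compound 4 (0.15 log units; within the scatter).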

Compound 4, half-maximal inhibitory concentration: 14500 nM
Compound 4: middle estimate off by 3.1-fold (0.49 log units), on the high side; the measured number lies below the stated range.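

At this place on the nitrogen, a nitro group is not required for a readable number: in this assay, 3-chloro-4-fluorophenyl in place of 3-nitrophenyl gives a 2.2-fold lower number from compound 3 to compound 4 (0.34 log units; beyond the scatter). Replacing the two groups with limit values now gives floors beyond the scatter, an at least 3.4-fold lower number from compound 2 to compound 4 (0.53 log units; beyond the scatter) and an at least 3.4-fold lower number from compound 1 to compound 4 (0.53 log units; beyond the scatter). These steps remain floors, not sizes: the limit of > 50000 nM in this assay, at which 2 of the 4 values shown sit.

Whether the chloro or the fluoro group accounts for the step stays open. So does what an amine or a methoxy group on this ring would give.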